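The source may hold more compounds than are shown below. What is called first, only, known or untested is meant among the compounds shown, and "the series" means these compounds.

Among the compounds with values here, compound 2, `COc1ccc(CCC(=O)/C=C/[C@H](O)Cc2ccccc2)cc1OC`, gives 22300 nM in a functional assay on U-937 cells (Homo sapiens) for antiproliferative activity, read by MTT assay, with a stated time of 48 h (a lower number here means a stronger inhibitor, a higher number a weaker inhibitor), the lowest of the two numbers measured so far; compound 1, `O=C(/C=C/[C@@H](O)Cc1ccccc1)CCc1ccccc1`, gives 168000 nM in this assay, a gap beyond the scatter. Compound 3, `COc1ccc(CCC(=O)/C=C/[C@@H](O)Cc2ccccc2)cc1OC`, is the next case. Relative to compound 2 it shows (the two compounds have the same atoms and bonds and differ only in configuration as drawn: 1 of 2 stereo elements differ; a stereocentre at a saturated chain carbon is drawn R in compound 2 and S in compound 3). Within the data shown here, no step between measured compounds differing in one place is available, so the weight of inversion at this centre is unknown. An expected step of a 1.3-fold higher number from compound 2 to compound 3 (0.13 log units; within the scatter) is assumed, small and most likely within the scatter, if anything toward a slightly higher number. Compound 3 is estimated at 30000 nM, with a range from 8000 nM to 90000 nM.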

Compound 3, half-maximal inhibitory concentration: 31900 nM
Estimate against measurement, compound 3: 1.1-fold (0.03 log units) below, and the stated range covers the measured number.
By their numbers in this assay, from the lowest: compounds 2 and 3 (each within the scatter of the next); then compound 1.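

In this assay, inversion at this saturated chain carbon gives a 1.4-fold higher number from compound 2 to compound 3 (0.16 log units; within the scatter), so the R and S forms as drawn cannot be told apart at this centre. Earlier compounds gave no reading of configuration here, whereas this pair isolates it: the fact that compounds 2 and 3 differ only in the configuration as drawn. The reading rests on this one pair, so it does not extend to the rest of the series.

From the compounds shown here alone, whether configuration stays equally silent with an amine on this carbon remains open. A longer chain on the shared core is equally untested for this centre.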